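A few compounds are considered here, and "the series" means these few. Any claim that something is new, unique, unknown or untested is made for them only; others in the source may bear on it.

Compound 1 `Cc1cccc(S(=O)(=O)NCc2ccc(CNC(=O)c3ccccc3C)cc2)c1` and compound 2 `Cc1ccccc1C(=O)NCc1ccc(CNS(=O)(=O)c2ccccc2F)cc1` share a core and differ only in the aryl group on the sulfonyl sulfur. In an assay on MDA-MB-231 cells for displacement of a labelled ligand from C-X-C chemokine receptor type 4 (Homo sapiens), read by fluorescence and microscopy, with stated times of 10 min and 30 min (on this read-out higher numbers stand for an effect only at larger amounts of compound and lower numbers for an effect already at smaller amounts), compound 1 gives 1000 nM, and in this assay compound 2 gives 1000 nM. For the measured compounds named here, the one measured step, no change at the digits printed from compound 1 to compound 2 (within the scatter), lies within the scatter, so compound 2 stands level with compound 1 on these numbers. Compound 3 `Cc1ccccc1C(=O)NCc1ccc(CNS(=O)(=O)c2cccc(F)c2)cc1` carries the same atoms as compound 2 joined differently: 3-fluorophenyl in place of 2-fluorophenyl on a sulfonyl sulfur. Going by the values given here, the only step that bears on this change is no change at the digits printed from compound 1 to compound 2 (within the scatter), where a different aryl group on the same sulfur left the read-out unchanged; no measured pair shows a move of fluorine around the ring. Compound 3 is therefore expected to show no change at the digits printed from compound 2 to compound 3 (within the scatter), no change beyond the scatter. The estimate for compound 3 in this assay is 1000 nM, with a range from 500 nM to 2000 nM.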

Compound 3, effective concentration (reported as EC, without a stated level of effect): 100 nM
Compound 3: middle estimate off by 10-fold (1.00 log units), on the high side; the whole stated range lies above it.
By their numbers in this assay, from the lowest: compound 3; then compounds 1 and 2 (each within the scatter of the next).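

The place of the fluorine on the aryl group borne by the sulfonyl sulfur matters in this assay: the same atoms joined differently give a 10-fold lower number from compound 2 to compound 3 (1.00 log units; beyond the scatter), a response that the flat step between the two earlier compounds had not revealed. Fluoro in place of methyl on an aromatic carbon likewise gives a 10-fold lower number from compound 1 to compound 3 (1.00 log units; beyond the scatter), so the level reading of compound 1 and compound 2 did not mean that this aryl group was insensitive to change. No measured evidence at hand accounts for either step.

From the compounds shown here alone, it remains open whether the lower number belongs to fluorine alone or would also hold with chloro, methoxy or a nitrile in its place. Whether an amine or a carboxylic acid would be tolerated on this aryl group is also unresolved.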